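The source may hold more compounds than are shown below. What is called first, only, known or untested is meant among the compounds shown, and "the series" means these compounds.

Working notes on the series in a functional assay on ML1 cells (Homo sapiens) for antiproliferative activity, read by WST assay, with a stated time of 3 days; on this read-out higher numbers stand for weaker inhibition and lower numbers for stronger inhibition. Compound 1 `N#Cc1cc(=O)[nH]c(=O)n1[C@@H]1O[C@H](CO)[C@@H](O)[C@H]1O` gives > 50000 nM, which is a limit of the assay. Compound 2 `O=c1cc(I)n([C@@H]2O[C@H](CO)[C@@H](O)[C@H]2O)c(=O)[nH]1` gives a measured number, 15300 nM. Compound 3 `O=c1cc(NO)n([C@@H]2O[C@H](CO)[C@@H](O)[C@H]2O)c(=O)[nH]1` gives > 50000 nM, also a limit of the assay. Compound 3 therefore stands at the limit of > 50000 nM in this assay, at which 2 of the 3 values shown sit.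

The next change leads to compound 4 `O=Cc1cc(=O)[nH]c(=O)n1[C@@H]1O[C@H](CO)[C@@H](O)[C@H]1O`: formyl in place of hydroxyamino on an aromatic carbon, which puts formyl in place of hydroxyamino on an aromatic carbon. Three measured exchanges at this carbon bear on it. Iodo for cyano gives an at least 3.2-fold lower number from compound 1 to compound 2 (0.51 log units; beyond the scatter). Hydroxyamino for iodo gives an at least 3.2-fold higher number from compound 2 to compound 3 (0.51 log units; beyond the scatter). Hydroxyamino for cyano gives a step that the two limits leave unreadable from compound 1 to compound 3. Only the iodo compound reaches a number, while compound 1 and compound 3, without iodo, both stay at the limit. Formyl is likewise not iodo, so no step beyond the scatter is expected in this assay, and a reading at the limit is quite possible. The estimated step is an at least 1.2-fold lower number from compound 3 to compound 4 (0.09 log units; that floor lies within the scatter). Compound 4 is expected at 40000 nM, within an estimated range of 12000 nM to 80000 nM.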

Compound 4, half-maximal inhibitory concentration: > 50000 nM
Compound 4 was reported as a limit; the forecaster's own chance of this, stated with the estimate: 65%; middle value at least 1.2-fold (0.09 log units) from the limit.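

In this assay formyl at this aromatic carbon falls on the same side as cyano and hydroxyamino, not with iodo, with an at least 3.2-fold higher number from compound 2 to compound 4 (0.51 log units; beyond the scatter) in this exchange. A carbonyl-bearing group with no hydrogen-bond donors thus ends at the same limit as hydroxyamino, which has donors, so among the compounds shown this difference between the two groups brings no readable change, and the limit is now the most common reading: the limit of > 50000 nM in this assay, at which 3 of the 4 values shown sit. The steps among compound 1, compound 3 and compound 4 cannot be read, as each joins two limits.

On these data alone, whether any group other than iodo at this carbon reaches a measured number stays open, for example bromo, an amine, a carboxylic acid or a longer chain. Also open, as far as these compounds go, is how far compound 1, compound 3 and compound 4 lie from one another beyond the limit.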